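This account rests on a few compounds, and the source may have more. Where it says the series, first, only, none or still open, it means among the compounds named here.

Compound 1, `CCC1(Cc2ccccc2)OS(=O)(=O)C=C1OCC(=O)OC`: in an ADME assay on HEL cells (Homo sapiens) for cytotoxicity, with a stated time of 3 days (a higher number here means that more compound is tolerated, a lower number that less compound is tolerated), compound 1 gives > 200000 nM, a limit of the assay.
Compound 2, `CCC1(Cc2ccccc2)OS(=O)(=O)C=C1OCc1ccc(F)cc1`: compound 2 gives > 50000 nM, again a limit.
Compound 3, `CCC1(Cc2ccccc2)OS(=O)(=O)C=C1OCc1ccc(OC)cc1`: compound 3 gives > 200000 nM, also a limit.

Compound 3 thus stands at the limit of > 200000 nM in this assay, at which 2 of the 3 values shown sit, where compound 1 also sits, while compound 2 sits at the limit of > 50000 nM in this assay, at which 1 of the 3 values shown sits. Compound 4, `CCC1(Cc2ccccc2)OS(=O)(=O)C=C1OCc1ccc([N+](=O)[O-])cc1`, differs from compound 3 by nitro in place of methoxy on an aromatic carbon. The nearest measured step is the change at the same aromatic carbon, a step that the two limits leave unreadable from compound 2 to compound 3, and the other steps, a step that the two limits leave unreadable from compound 1 to compound 3 and a step that the two limits leave unreadable from compound 1 to compound 2, are likewise unreadable between limits. No direction can be read from them; compound 4 is therefore expected to remain at the limit, and a number no higher from compound 3 to compound 4 (the limit leaves the size open) is the step this expectation implies. For compound 4 the estimate is 200000 nM, between 50000 nM and 300000 nM.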

Compound 4, half-maximal cytotoxic concentration: < 200000 nM
Compound 4: no number, only a limit; the forecaster's own chance of this, stated with the estimate: 80%; the middle value sits exactly at the limit.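

In this assay, among the compounds shown here, nitro in place of methoxy on this aromatic carbon gives a number no higher from compound 3 to compound 4 (the limit leaves the size open), the first change here with a readable direction. The change at the chain carbon likewise gives a number no higher from compound 1 to compound 4 (the limit leaves the size open). Compound 4 is the only compound at this limit: the limit of < 200000 nM in this assay, at which 1 of the 4 values shown sits.

On these data alone, the step between compound 2 and compound 4 cannot be read, and the actual value of compound 4 remains open. Also open, as far as these compounds go, is how an amine or a carboxylic acid on this aromatic carbon would read in this assay.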